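Amide Nitrogen Methylation in a Pyrazole Dihydroxyheptanoic Acid Series

A few compounds are considered here, and "the series" means these few. Any claim that something is new, unique, unknown or untested is made for them only; others in the source may bear on it.

Compound 1 `CC(C)c1c(C(=O)NCC2CCCCC2)nn(-c2ccc(F)cc2)c1OC[C@@H](O)C[C@@H](O)CC(=O)O`, compound 2 `Cc1cccc(CNC(=O)c2nn(-c3ccc(F)cc3)c(OC[C@@H](O)C[C@@H](O)CC(=O)O)c2C(C)C)c1` and compound 3 `CC(C)c1c(C(=O)NCc2ccc(Cl)cc2)nn(-c2ccc(F)cc2)c1OC[C@@H](O)C[C@@H](O)CC(=O)O` share one core and differ only in the amide substituent. In a functional assay on L6 cells (Rattus norvegicus) for inhibition (on this read-out higher numbers stand for weaker inhibition and lower numbers for stronger inhibition), compound 2 gives 280 nM. In this assay compound 1 gives "not determined" (no result reported), so no number was reported for it. In this assay compound 3 likewise gives "not determined" (no result reported), so its standing rests on no single value, and the step to compound 4 cannot be measured against a starting point. Compound 4 `CC(C)c1c(C(=O)N(C)Cc2ccc(F)cc2)nn(-c2ccc(F)cc2)c1OC[C@@H](O)C[C@@H](O)CC(=O)O` differs from compound 3 by (4-fluorobenzyl)(methyl)amino in place of (4-chlorobenzyl)amino on a carbonyl carbon; the change removes the single hydrogen-bond donor of the amide. Compound 4 is expected to land near 600 nM in this assay, within a range from 150 nM to 3000 nM, a wide estimate since only compound 2 offers a measured anchor.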

Compound 4, half-maximal inhibitory concentration: 2800 nM
Compound 4: middle estimate off by 4.7-fold (0.67 log units), on the low side; the range from low to high includes it.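

In this assay this amide position now shows a measured change, a 10-fold higher number from compound 2 to compound 4 (1.00 log units; beyond the scatter) which means weaker inhibition with (4-fluorobenzyl)(methyl)amino on the carbonyl carbon than with (3-methylbenzyl)amino. Compound 3 has no number, so the step from it cannot be read. No measured evidence here accounts for the difference. Between compound 2 and compound 4, the methyl on the amide nitrogen and the ring substituent both change, so their separate shares remain unknown. A (3-methylbenzyl)(methyl)amino or (4-fluorobenzyl)amino group would tell them apart.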